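Triazolyl in place of phenyl on the propyl chain

The source may hold more compounds than are shown below. What is called first, only, known or untested is meant among the compounds shown, and "the series" means these compounds.

Measured so far:
compound 1 `CCCCNc1nc(N)nc(C)c1CCCc1ccccc1` — 749 nM
compound 2 `CCCCCc1c(C)nc(N)nc1NCCCC` — 1220 nM

In an assay on HEK293 cells for agonist activity at Toll-like receptor 8 (Homo sapiens), read by spectrophotometry (on this read-out lower numbers stand for an effect already at smaller amounts and higher numbers for an effect only at larger amounts of compound), compound 1 gives 749 nM, the lowest of the two numbers; the nearest is compound 2, with a 1.6-fold higher number from compound 1 to compound 2 (0.21 log units; within the scatter). Compound 3 `CCCCNc1nc(N)nc(C)c1CCCn1cncn1` differs from compound 1 by 1H-1,2,4-triazol-1-yl in place of phenyl on a saturated chain carbon, three bonds along the chain from an aromatic carbon. Among the measured compounds shown here, the only measured step at this place is the one from compound 1 to compound 2, which stayed within the scatter, so a ring on that chain carbon appears to be exchangeable without a large shift. For compound 3 a step of about a 1.6-fold higher number from compound 1 to compound 3 (0.20 log units; within the scatter) is therefore expected, not clearly beyond the scatter. The estimate for compound 3 is 1200 nM, with a range from 400 nM to 4000 nM.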

Compound 3, half-maximal effective concentration: 1050 nM
Estimate against measurement, compound 3: 1.1-fold (0.06 log units) above, within the range that was stated.
By their numbers in this assay, from the lowest: compounds 1, 3 and 2 (each within the scatter of the next).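

In this assay the entry of 1H-1,2,4-triazol-1-yl gives a 1.4-fold higher number from compound 1 to compound 3 (0.15 log units; within the scatter) and a 1.2-fold lower number from compound 2 to compound 3 (0.07 log units; within the scatter) on the same saturated chain carbon. This place therefore accepts a five-membered aromatic ring with 3 hetero atoms and 3 hydrogen-bond acceptors, as well as phenyl or ethyl, with no step among these compounds beyond the scatter. No measured evidence bears on this result. Still open, going by these compounds, is whether a primary amine or a carboxylic acid at this place would move the number beyond the scatter. On these data alone, a longer chain in place of the propyl chain is equally open.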